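Solubility Across Aryl Variants of a Shared Core

This account rests on a few compounds, and the source may have more. Where it says the series, first, only, none or still open, it means among the compounds named here.

Compound 1 `Cc1cc(NCc2ccccn2)n2ncc(-c3ccc(F)cc3)c2n1`: < 5000 nM
Compound 2 `Cc1cc(NCc2ccccn2)n2ncc(-c3ccccc3F)c2n1`: 5000 nM
Compound 3 `Cc1cc(NCc2ccccn2)n2ncc(-c3ccsc3)c2n1`: 9000 nM

In a physicochemical assay for solubility, read by HPLC, using the shake flask method, measured as kinetic solubility, with a stated time of 2 h, at pH 7.4 (on this read-out higher numbers stand for higher solubility and lower numbers for lower solubility), compound 3 gives the highest of the two numbers, and the nearest step a 1.8-fold higher number from compound 2 to compound 3 (0.26 log units; within the scatter) lies within the scatter. For compound 1 the result < 5000 nM is a limit of the assay, not a number. The step of an at least 1.8-fold higher number from compound 1 to compound 3 (0.25 log units; that floor lies within the scatter) has a floor within the scatter, while a number no lower from compound 1 to compound 2 (the limit leaves the size open) is of unreadable size. Compound 4 `Cc1cc(NCc2ccccn2)n2ncc(-c3ccc(F)cc3C)c2n1` carries 4-fluoro-2-methylphenyl in place of thiophen-3-yl on an aromatic carbon. Both measured steps onto thiophen-3-yl ran upward by small amounts. The reverse change, onto 4-fluoro-2-methylphenyl, is expected to give a 2.6-fold lower number from compound 3 to compound 4 (0.41 log units; beyond the scatter), a modest downward move, with a fair chance of another limit as the limit of < 5000 nM in this assay, at which 1 of the 3 values shown sits, shows. Compound 4 is estimated at 3500 nM, between 1500 nM and 9000 nM.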

Compound 4, solubility: 42300 nM
Compound 4: middle estimate off by 12-fold (1.08 log units), on the low side, and the stated range ends below it.
By their numbers in this assay, from the lowest: compounds 2 and 3 (each within the scatter of the next); then compound 4.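

Within the data shown here, at this aromatic carbon, the group can shift the result in this assay beyond the scatter, which no earlier readable step did: the change to 4-fluoro-2-methylphenyl gives a 4.7-fold higher number from compound 3 to compound 4 (0.67 log units; beyond the scatter) and an 8.5-fold higher number from compound 2 to compound 4 (0.93 log units; beyond the scatter) in the two comparisons with a measured start. Methyl in place of hydrogen on an aromatic carbon gives an at least 8.4-fold higher number from compound 1 to compound 4 (0.92 log units; beyond the scatter) as well, with a floor beyond the scatter. Nothing shown gives a cause for this rise.

On these data alone, whether an ethyl, a methoxy or a chlorine in place of that methyl would give a similar rise stays open. So does the effect of an amine on the same phenyl ring.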